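Swapping furan-2-yl for phenyl at the assay limit

The source may report more compounds than this note shows. Statements on the series, on what has been measured and on what is new or still open speak of the compounds shown alone.

Among the measured compounds shown here, only two compounds have readings so far. In a functional assay on K562 cells (Homo sapiens), read by MTT assay, with a stated time of 72 h (on this read-out lower numbers stand for stronger inhibition and higher numbers for weaker inhibition), compound 1 `C#Cc1cn([C@@H]2O[C@H](CO)[C@@H](O)[C@H]2O)c2ncnc(N(C)C)c12` gives 260 nM as a true measured number. In this assay compound 2 `Nc1nc2c(c(-c3ccco3)cn2[C@@H]2O[C@H](CO)[C@@H](O)[C@H]2O)c(=O)[nH]1` reads > 20000 nM and this is a limit of the assay, not a number. That places compound 2 at the limit of > 20000 nM in this assay, at which 1 of the 2 values shown sits, in this small set.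

Compound 3 `Nc1nc2c(c(-c3ccccc3)cn2[C@@H]2O[C@H](CO)[C@@H](O)[C@H]2O)c(=O)[nH]1` keeps the core of compound 2 and alters one group: phenyl in place of furan-2-yl on an aromatic carbon of the five-membered aromatic ring with 1 nitrogen. For the measured compounds named here, no measured pair in this set shows what such a swap does, so any forecast here is a cautious one. Compound 3 has its closest measured relative in compound 2. The limit of compound 2 at > 20000 nM is the main guide to the forecast. The estimated step that the limit leaves unreadable from compound 2 to compound 3 is expected to stay within the usual scatter, with no direction favoured. For compound 3 the expected value is 25000 nM with an estimated range from 10000 nM to 60000 nM and a reading at the assay limit is the likeliest outcome.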

Compound 3, half-maximal inhibitory concentration: > 20000 nM
Compound 3 gave a limit, no number; the forecaster's own chance of this, stated with the estimate: 75%; the middle value is on the limit's open side.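

Compound 3 reads > 20000 nM in this assay, which is a limit of the assay and not a number. Compound 2 also reads as a limit, so no step can be read between compound 2 and compound 3: the limit of > 20000 nM in this assay, at which 2 of the 3 values shown sit.

The compounds shown leave open how far phenyl and furan-2-yl actually differ on this core.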